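The compounds below may be only part of what the source reports. "The series", "measured", "known", "first", "only" and "open" are said of these compounds alone.

Of the compounds shown here, three have been measured in a functional assay on KARPAS-299 cells (Homo sapiens) for antiproliferative activity, read by MTT assay, with a stated time of 4 h; a higher number here means a weaker inhibitor, a lower number a stronger inhibitor.

Compound 1, `COC(=O)c1cccn1-c1ccc(Nc2ncc(Cl)c(Nc3ccccc3NS(C)(=O)=O)n2)c(OC)c1`, gives 790 nM.
Compound 2, `COc1cc(-n2cccc2C(=O)O)ccc1Nc1ncc(Cl)c(Nc2ccccc2NS(C)(=O)=O)n1`, gives 90 nM.
Compound 3, `COc1cc(-n2cccc2C(=O)NCCO)ccc1Nc1ncc(Cl)c(Nc2ccccc2NS(C)(=O)=O)n1`, gives 45 nM.

All three share the same core and differ only in the group attached to the carbonyl carbon on the pyrrole ring. Compound 3 has the lowest number of the three. Its nearest neighbour is compound 2: a 2.0-fold lower number from compound 2 to compound 3 (0.30 log units; within the scatter), which does not separate the two. Its furthest is compound 1: an 18-fold lower number from compound 1 to compound 3 (1.24 log units; beyond the scatter). The other shown step, an 8.8-fold lower number from compound 1 to compound 2 (0.94 log units; beyond the scatter), shows that most of that gap opens once the methyl ester is replaced.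

Compound 4, `COc1cc(-n2cccc2C(=O)N2CC(O)C2)ccc1Nc1ncc(Cl)c(Nc2ccccc2NS(C)(=O)=O)n1`, differs from compound 3 at this same position: 3-hydroxyazetidin-1-yl in place of (2-hydroxyethyl)amino on a carbonyl carbon. Among the measured compounds shown here, the step that bears most directly on this change is the one from compound 2 to compound 3, where the carbonyl substituent was also exchanged while the rest of the molecule stayed fixed, and that step stayed within the scatter. Both groups carry a hydroxy-bearing chain on the carbonyl nitrogen, so no step beyond the scatter in this assay is expected, in either direction.

Compound 4 is therefore estimated to give 55 nM, with a range from 20 nM to 150 nM. The step this estimate implies is a 1.2-fold higher number from compound 3 to compound 4 (0.09 log units; within the scatter).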

Compound 4, half-maximal inhibitory concentration: 81 nM
Compound 4: the middle estimate sits 1.5-fold (0.17 log units) below what was measured; the range from low to high includes it.
By their numbers in this assay, from the lowest: compounds 3, 4 and 2 (each within the scatter of the next); then compound 1.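

The 3-hydroxyazetidin-1-yl group places a four-membered ring on the carbonyl carbon and has no amide hydrogen, yet this swap for the open (2-hydroxyethyl)amino chain does not separate the two amides in this assay (a 1.8-fold higher number from compound 3 to compound 4 (0.26 log units; within the scatter)). The new amide also cannot be told apart from the carboxylic acid (a 1.1-fold lower number from compound 2 to compound 4 (0.05 log units; within the scatter)), whereas the methyl ester remains clearly apart from it (a 9.8-fold lower number from compound 1 to compound 4 (0.99 log units; beyond the scatter)), so among these four compounds only compound 1 stands away from the others. Nothing measured here accounts for these numbers.

Both amides carry a hydroxy group, so the compounds shown leave open whether it matters at all, which a plain azetidin-1-yl or ethylamino group on the same carbonyl carbon would test. Also open, going by these compounds, is how far this position tolerates further change, for example a longer chain such as (3-hydroxypropyl)amino, a larger ring such as 4-hydroxypiperidin-1-yl, or a chain ending in an amine.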